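The source may report more compounds than this note shows. Statements on the series, on what has been measured and on what is new or still open speak of the compounds shown alone.

Measured compounds in the series:
- compound 1 `Cn1cnc(CN2CCN(c3cccc4[nH]c(-c5ccc(C(C)(C)C)cc5)nc34)CC2)c1`: 98 nM
- compound 2 `CCc1nc(C)c(CN2CCN(c3cccc4[nH]c(-c5ccc(C(C)(C)C)cc5)nc34)CC2)o1`: 320 nM
- compound 3 `CCc1cc(CN2CCN(c3cccc4[nH]c(-c5ccc(C(C)(C)C)cc5)nc34)CC2)n(C)n1`: 250 nM

All three values come from an assay on isolated protein for displacement of a labelled ligand from Gonadotropin-releasing hormone receptor (Rattus norvegicus); a lower number here means a stronger inhibitor, a higher number a weaker inhibitor. Compound 3 stands second highest of the three numbers; its nearest neighbour is compound 2, with a 1.3-fold lower number from compound 2 to compound 3 (0.11 log units; within the scatter), so these two are not separated. The gap to compound 1 is wider: a 2.6-fold higher number from compound 1 to compound 3 (0.41 log units; beyond the scatter).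

The next compound, compound 4 `CCCn1cnc(CN2CCN(c3cccc4[nH]c(-c5ccc(C(C)(C)C)cc5)nc34)CC2)c1C`, is not yet measured. The change from compound 3 is 5-methyl-1-propyl-1H-imidazol-4-yl in place of 3-ethyl-1-methyl-1H-pyrazol-5-yl on a saturated chain carbon bound to an amine nitrogen in a ring. Among the compounds with values here, no measured step covers this exact exchange. What bears on it is that compound 1 carries a 1-methyl-1H-imidazol-4-yl at the same place and gives the lowest number of the three, with a 3.3-fold higher number from compound 1 to compound 2 (0.51 log units; beyond the scatter) and a 2.6-fold higher number from compound 1 to compound 3 (0.41 log units; beyond the scatter) both beyond the scatter, while a 1.3-fold lower number from compound 2 to compound 3 (0.11 log units; within the scatter) shows the oxazole and pyrazole as equivalent. Within the data shown here, compound 4 returns to an imidazol-4-yl, but with a 5-methyl and a 1-propyl that compound 1 lacks, and no measured pair tells how those two groups act. A modest step downwards is therefore expected in this assay, roughly back toward the number of compound 1, with wide uncertainty: a 1.7-fold lower number from compound 3 to compound 4 (0.22 log units; within the scatter). Compound 4 is estimated at 150 nM, in the range 50 nM to 450 nM.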

Compound 4, half-maximal inhibitory concentration: 47 nM
Estimate against measurement, compound 4: 3.2-fold (0.50 log units) above; the whole stated range lies above it.
By their numbers in this assay, from the lowest: compound 4; then compound 1; then compounds 3 and 2 (each within the scatter of the next).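

In this assay, the imidazol-4-yl ring tolerates added substitution on a saturated chain carbon bound to an amine nitrogen in a ring: with the 5-methyl-1-propyl-1H-imidazol-4-yl group in place of 1-methyl-1H-imidazol-4-yl, there is a 2.1-fold lower number from compound 1 to compound 4 (0.32 log units; beyond the scatter), and compound 4 is the strongest inhibitor of the four. The same group gives larger separations from the pyrazole, with a 5.3-fold lower number from compound 3 to compound 4 (0.73 log units; beyond the scatter), and from the oxazole, with a 6.8-fold lower number from compound 2 to compound 4 (0.83 log units; beyond the scatter), so both imidazole compounds now have lower numbers than compound 2 and compound 3, with no exception among the four. No accompanying measurement accounts for these steps.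

Compound 4 differs from compound 1 in both the 5-methyl and the 1-propyl, which leaves open how the step divides between these two groups. Also open, as far as these compounds go, is whether a longer chain such as butyl at the ring nitrogen, or an amine or a carboxylic acid at the end of the propyl chain, would hold the number of compound 4 in this assay.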